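Aminothiophene series: carbamoyl to cyano on the core

The source may report more compounds than this note shows. Statements on the series, on what has been measured and on what is new or still open speak of the compounds shown alone.

Values in an in vitro assay on CHOk1 cells with adenosine receptor A1 (Homo sapiens) as the target (a lower number here means that less compound is needed, a higher number that more compound is needed for the effect), measured so far:
compound 1, `NNC(=O)c1c(N)sc2c1CCN(Cc1ccccc1)C2`: 8900 nM
compound 2, `NC(=O)c1c(N)sc2c1CCN(Cc1ccccc1)C2`: > 20000 nM

Compound 2 stands at a limit of the assay only, so where it sits in this assay is known as a bound and not as a number (the limit of > 20000 nM in this assay, at which 1 of the 2 values shown sits). Among the measured compounds shown here, compound 1 is the only member of the pair with an actual number, and that number is itself high. For the measured compounds named here, the single measured step, an at least 2.2-fold higher number from compound 1 to compound 2 (0.35 log units; beyond the scatter), runs toward a higher number and leaves compound 2 beyond the measurable range of this assay.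

Compound 3, `N#Cc1c(N)sc2c1CCN(Cc1ccccc1)C2`, differs from compound 2 by cyano in place of carbamoyl on an aromatic carbon. The measured step bears on this change only loosely, since it alters the same carbamoyl-bearing position but from the other side, and it moved the number up rather than down. No step beyond the scatter toward a lower number is therefore expected, and the step of a number no higher from compound 2 to compound 3 (the limit leaves the size open) is the expected outcome. For compound 3 in this assay the estimate is 20000 nM, with a range from 5000 nM to 60000 nM, and a limit rather than a number is judged the more likely report.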

Compound 3, half-maximal effective concentration: 15200 nM
Compound 3: the middle estimate sits 1.3-fold (0.12 log units) above what was measured, within the range that was stated.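

In this assay, cyano in place of carbamoyl on this aromatic carbon gives a compound with a measured number, and the step reads an at least 1.3-fold lower number from compound 2 to compound 3 (0.11 log units; that floor lies within the scatter). As far as these compounds go, compound 2 stands at a limit and not at a number, so the true size of this step is unknown: the limit of > 20000 nM in this assay, at which 1 of the 3 values shown sits. Among the compounds shown here, the comparison with the aminocarbamoyl group reads a 1.7-fold higher number from compound 1 to compound 3 (0.23 log units; within the scatter), so a measurable number at this position does not depend on the amino group on the amide-type nitrogen, and a group without any amide nitrogen gives a number within the scatter of the one seen with that group.

The cyano and aminocarbamoyl compounds both remain high in this assay, and the compounds shown do not tell whether any group at this aromatic carbon can bring the number far lower. From the compounds shown here alone, a carboxylic acid or a methyl ester at this carbon would test that directly, while the amino group on the thiophene ring and the benzyl group on the shared core stay unchanged throughout these compounds, so their contribution remains open.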